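From a Chlorophenyl Sulfide to a Phenethyl Sulfide

The compounds below may be only part of what the source reports. "The series", "measured", "known", "first", "only" and "open" are said of these compounds alone.

Of the compounds shown here, two have so far been measured in a functional assay on HCT-116 cells (Homo sapiens) for inhibition, read by CCK-8 assay, with a stated time of 72 h, tested at 8 uM; on this read-out lower numbers stand for less inhibition of growth and higher numbers for more inhibition of growth at the one concentration tested. Compound 1 `Nc1ccccc1NC(=O)/C=C/c1ccc(CSc2ccc(Cl)cc2)cc1` gives 3.27% in this assay, the lowest of the two numbers. Within the data shown here, compound 2 `CC(C)(C)c1ccc(SCc2ccc(C(=O)Nc3ccccc3N)cc2)cc1` gives 60.5% in this assay, a number that stands beyond the scatter above compound 1; the two compounds differ from each other in more than one place, so no single step connects them.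

Compound 3 `Nc1ccccc1NC(=O)/C=C/c1ccc(CSCCc2ccccc2)cc1` has not yet been measured. It arises from compound 1 through one change: phenethyl in place of 4-chlorophenyl on a sulfur. Among the measured compounds shown here, no step between measured compounds concerns this change, so any forecast rests on compound 1 alone, whose reading of 3.27% leaves little room for a lower number. A small rise is the most that is expected, and the step of a number 6.7 percentage points higher from compound 1 to compound 3 (within the scatter) is expected to remain within the scatter. For compound 3 the estimated growth inhibition in this assay is 10%, with a range from 0% to 30%.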

Compound 3, percent growth inhibition at one concentration: 10.6%
Estimate against measurement, compound 3: 0.6 percentage points below; low and high end bracket the measured number.
By their numbers in this assay, from the lowest: compounds 1 and 3 (each within the scatter of the next); then compound 2.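

Phenethyl in place of 4-chlorophenyl on a sulfur, the only step at this position shown here, gives a number 7.3 percentage points higher from compound 1 to compound 3 (within the scatter) in this assay at the one concentration tested. Both groups carry one six-membered aromatic ring of carbon only, so this exchange of 7 heavy atoms including a chlorine for 8 heavy atoms of carbon only does not move the reading of the core of compound 1 beyond the usual scatter. Nothing on hand explains this outcome or connects it to a measured property of either group.

From the compounds shown here alone, whether a carboxylic acid, an amine or a longer chain on this sulfur would give a reading outside the scatter of compound 1 in this assay remains open. Going by these compounds, it is also open whether the same exchange would leave the reading unchanged on another core, and compound 2 gives no reading of this change, as it differs from compound 1 in more than one place.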